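Urea aryl swap on a shared core: halogens to methoxy

The source may hold more compounds than are shown below. What is called first, only, known or untested is meant among the compounds shown, and "the series" means these compounds.

The series shares one core carrying an aryl urea, and is compared in a functional assay on HepG2 cells (Homo sapiens) for antiproliferative activity, read by MTT assay, with a stated time of 48 h; a lower number here means a stronger inhibitor, a higher number a weaker inhibitor. Compound 1 `O=C(Nc1cccc(CNc2nccnc2Cl)c1)Nc1cccc2ccccc12` gives only a limit of the assay, > 40000 nM; that limit is recorded as the limit of > 40000 nM in this assay, at which 1 of the 3 values shown sits. Compound 2 `O=C(Nc1cccc(CNc2nccnc2Cl)c1)Nc1ccc(Cl)cc1Br` gives 6720 nM, which stands as the higher of the two numbers obtained, although compound 3 `O=C(Nc1cccc(CNc2nccnc2Cl)c1)Nc1cccc(C(F)(F)F)c1` with 6210 nM lies within the usual scatter of it, so the two cannot be told apart. For the measured compounds named here, no two measured compounds differ in a single place, so no measured step is available as a guide.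

Compound 4 `COc1ccccc1NC(=O)Nc1cccc(CNc2nccnc2Cl)c1` differs from compound 2 in one place, (2-methoxyphenyl in place of 2-bromo-4-chlorophenyl on an amide-type nitrogen). The expectation for this change is a step toward a weaker inhibitor, by a modest margin that may or may not exceed the scatter, so that compound 4 is estimated at 12000 nM in this assay, within a range from 4000 nM to 40000 nM, a step of a 1.8-fold higher number from compound 2 to compound 4 (0.25 log units; within the scatter).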

Compound 4, half-maximal inhibitory concentration: 13700 nM
For compound 4 the middle estimate is 1.1-fold (0.06 log units) below the measured one; low and high end bracket the measured number.
By their numbers in this assay, from the lowest: compounds 3 and 2 (each within the scatter of the next); then compound 4. At a limit, above all of these: compound 1.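

In this assay, this position now has its first measured single-place step, 2-methoxyphenyl in place of 2-bromo-4-chlorophenyl on an amide-type nitrogen: a 2.0-fold higher number from compound 2 to compound 4 (0.31 log units; beyond the scatter), a modest move toward a weaker inhibitor. The earlier compounds shown here offered no such pair, and here both groups keep a six-membered aromatic ring of carbon only, so the step reflects a change in what that ring carries. Nothing measured here bears on why the number moved.

This single step cannot separate the loss of the bromine from the loss of the chlorine or the gain of the methoxy group. From the compounds shown here alone, how a phenyl ring carrying an amine, a nitrile or a carboxylic acid on this nitrogen would read in this assay also remains open.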